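The source may hold more compounds than are shown below. What is called first, only, known or untested is meant among the compounds shown, and "the series" means these compounds.

Measured so far:
- compound 1 `O=C(CN1CCN(C(=O)c2ccc(Cl)cc2)CC1)N1CCN(CCCc2c[nH]c3ccccc23)CC1` with 98200 nM
- compound 2 `COc1cccc(C(=O)N2CCN(CC(=O)N3CCN(CCCc4c[nH]c5ccccc45)CC3)CC2)c1` with 143000 nM

Going by the values given here, in an ADME assay on HEK293 cells (Homo sapiens) for cytotoxicity, read by MTT assay, with a stated time of 72 h (on this read-out lower numbers stand for stronger inhibition and higher numbers for weaker inhibition), compound 2 gives 143000 nM and sits within the scatter of compound 1, the only other measured compound. Compound 3 `O=C(CN1CCN(C(=O)c2ccccc2F)CC1)N1CCN(CCCc2c[nH]c3ccccc23)CC1` differs by one change 2-fluorophenyl in place of 3-methoxyphenyl on a carbonyl carbon that puts 2-fluorophenyl in place of 3-methoxyphenyl on a carbonyl carbon. Among the compounds with values here, the single measured step of a 1.5-fold higher number from compound 1 to compound 2 (0.16 log units; within the scatter) was also a swap on that carbonyl carbon and stayed within the scatter. No step beyond the scatter is therefore expected, and the estimated step of a 1.2-fold lower number from compound 2 to compound 3 (0.08 log units; within the scatter) is correspondingly small. For compound 3 the estimate is 120000 nM (expected range 60000 nM to 220000 nM).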

Compound 3, half-maximal inhibitory concentration: 133000 nM
For compound 3 the middle estimate is 1.1-fold (0.04 log units) below the measured one, within the range that was stated.
By their numbers in this assay, from the lowest: compounds 1, 3 and 2 (each within the scatter of the next).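

In this assay a third substituted phenyl on the carbonyl carbon stays within the scatter of both earlier ones (a 1.1-fold lower number from compound 2 to compound 3 (0.03 log units; within the scatter); a 1.4-fold higher number from compound 1 to compound 3 (0.13 log units; within the scatter)). Across these compounds, 2-fluorophenyl, 3-methoxyphenyl and 4-chlorophenyl therefore cannot be told apart at this position, although the ring carries a different group each time. No available evidence bears on why these numbers stay so close. Still open, from the compounds shown here alone, is whether a group other than a substituted phenyl, such as a simple amine or a carboxylic acid on a longer chain, would stay within this range.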